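A few compounds are considered here, and "the series" means these few. Any claim that something is new, unique, unknown or untested is made for them only; others in the source may bear on it.

In a functional assay for agonist activity at Free fatty acid receptor 1 (Homo sapiens), read by FLIPR, in the presence of a further agent that is not named here (a lower number here means that less compound is needed, a higher number that more compound is needed for the effect), three compounds have been measured. Compound 1 `O=C1NC(=O)C(Cc2ccc(Oc3ccc(C(F)(F)F)cn3)cc2)S1` gives 558 nM, compound 2 `O=C1NC(=O)C(Cc2ccc(Oc3ccc(Cl)cn3)cc2)S1` gives 1870 nM, and compound 3 `O=C1CC(Cc2ccc(Oc3ccc(Cl)cc3Cl)cc2)C(=O)N1`, built on a different core, gives 6450 nM. Compound 2 thus stands second highest of the three numbers, with compound 1 nearest and compound 3 furthest from it. For the measured compounds named here, the only single-point step among them is the one from compound 1 to compound 2, which brought a 3.4-fold higher number from compound 1 to compound 2 (0.53 log units; beyond the scatter).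

The untested compound 4 `O=C1NC(=O)C(Cc2ccc(Oc3ccccc3Cl)cc2)S1` differs from compound 2 by 2-chlorophenyl in place of 5-chloropyridin-2-yl on an oxygen on an aromatic ring. Going by the values given here, no measured step in this assay covers a change of this kind: the step from compound 1 to compound 2 concerns a different exchange, and compound 3 shares neither the core nor the ring of compound 4. Compound 3 does show that a chlorophenyl ether on a related scaffold gives a higher number than compound 2, but without a matched step this is only a hint. Compound 4 is therefore expected to give about 2600 nM, within 800 nM to 8500 nM, which would amount to an expected 1.4-fold higher number from compound 2 to compound 4 (0.14 log units; within the scatter).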

Compound 4, half-maximal effective concentration: 1190 nM
The estimate for compound 4 lay 2.2-fold (0.34 log units) above the measured number; low and high end bracket the measured number.
By their numbers in this assay, from the lowest: compound 1; then compounds 4 and 2 (each within the scatter of the next); then compound 3.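

In this assay, for the compounds shown here, this is the first measured exchange of the ring itself on the oxygen on an aromatic ring, with the shared core held constant: a 1.6-fold lower number from compound 2 to compound 4 (0.20 log units; within the scatter). The step lies within the scatter, so on this core 2-chlorophenyl, a ring of carbon only, cannot be told apart from 5-chloropyridin-2-yl, and the ring's hetero atom and its hydrogen-bond acceptor are not needed to keep the number in this range. Nothing measured here bears on the reason for this result.

The exchange alters the ring atoms and the place of the chloro group together, so these compounds cannot separate the two. Also open, going by these compounds, is what 2-(trifluoromethyl)phenyl would give at this place, or a carboxylic acid in place of the shared core.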